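Replacing the indolyl group on the shared core

The compounds below may be only part of what the source reports. "The series", "measured", "known", "first", "only" and "open" are said of these compounds alone.

In a functional assay on HeLa cells (Homo sapiens) for inhibition, read by CCK-8 assay, with a stated time of 48 h (on this read-out higher numbers stand for weaker inhibition and lower numbers for stronger inhibition), compound 1 `COc1cc(-c2ccnc3cc(-c4c[nH]c5ccccc45)nn23)cc(OC)c1OC` gives 195 nM, and compound 2 `COc1cc(-c2ccnc3cc(-c4ccc5cc[nH]c5c4)nn23)cc(OC)c1OC` gives 125 nM. Within the data shown here, these are the only two numbers so far, and they lie within the scatter of each other, so compound 2 stands level with compound 1.

Compound 3 `COc1cc(-c2ccnc3cc(-c4ccc(N(C)C)cc4)nn23)cc(OC)c1OC` keeps the shared core and differs from compound 2 in one group: 4-(dimethylamino)phenyl in place of 1H-indol-6-yl on an aromatic carbon. Here, 4-(dimethylamino)phenyl takes the place of 1H-indol-6-yl on an aromatic carbon.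

Among the measured compounds shown here, only one measured step bears on this place: a 1.6-fold lower number from compound 1 to compound 2 (0.19 log units; within the scatter). That step exchanges one indolyl group for another and stays within the scatter. For the measured compounds named here, it shows some tolerance among indolyl groups, but no measured compound carries a 4-(dimethylamino)phenyl group, so the evidence for this change is thin. A small shift in this assay, with no firm direction and no clear move beyond the scatter, is the working expectation. The expected change is a 1.4-fold higher number from compound 2 to compound 3 (0.16 log units; within the scatter). For compound 3 the estimate is 180 nM, with an expected range of 60 nM to 550 nM.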

Compound 3, half-maximal inhibitory concentration: 378 nM
Beside the measured number, compound 3's estimate is 2.1-fold (0.32 log units) below it; measured number inside the range.
By their numbers in this assay, from the lowest: compounds 2, 1 and 3 (each within the scatter of the next, the first and the last beyond it).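

Working notes on the group at this place, on an aromatic carbon of a five-membered aromatic ring with 2 nitrogen, part of a fused or bridged system of two rings. In this assay, among these compounds, the exchange of 1H-indol-6-yl for 4-(dimethylamino)phenyl gives the only step so far that lies beyond the scatter (a 3.0-fold higher number from compound 2 to compound 3 (0.48 log units; beyond the scatter)), so this place does not tolerate every aromatic group equally, although the step is modest. The same group set against 1H-indol-3-yl stays within the scatter (a 1.9-fold higher number from compound 1 to compound 3 (0.29 log units; within the scatter)), which means that the separation holds against one indolyl group only and that compound 3 is not clearly apart from both indolyl compounds. No measurement on hand accounts for the step.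

The exchange alters the ring count, the hydrogen-bond donor count and the hydrogen-bond acceptor count together, and the compounds shown do not pull these apart. On these data alone, an indolyl group with a methyl on its ring nitrogen, or an unsubstituted phenyl, would be the direct comparison, and how either would read out in this assay remains open.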